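The compounds below may be only part of what the source reports. "The series", "measured", "known", "first", "only" and "open" are said of these compounds alone.

The study compares four compounds in a functional assay on CCRF-CEM cells (Homo sapiens) for cytotoxicity, in the absence of a further agent; a higher number here means a weaker inhibitor, a lower number a stronger inhibitor. Compound 1 `Nc1nc(N)c(CCCN(Cc2ccc(NC(CCC(=O)O)C(=O)O)cc2)c2cc(F)c([N+](=O)[O-])cc2[N+](=O)[O-])c(O)n1` gives 51000 nM. Compound 2 `Nc1nc(N)c(CCCN(Cc2ccc(NC(CCC(=O)O)C(=O)O)cc2)c2cc(F)c(F)cc2[N+](=O)[O-])c(O)n1` differs from compound 1 by a single change, (fluoro in place of nitro on an aromatic carbon). For compound 2 the assay reports only a limit, > 100000 nM. The step of an at least 1.9-fold higher number from compound 1 to compound 2 (0.29 log units; that floor lies within the scatter) therefore points toward weaker inhibition, and its floor rests on (the limit of > 100000 nM in this assay, at which 1 of the 3 values shown sits). Compound 3 `Nc1nc(N)c(CCCNc2cc(F)c([N+](=O)[O-])cc2[N+](=O)[O-])c(O)n1` is built on another core; how the core of compound 3 differs from the core of compound 1 is not broken down here. In this assay compound 3 gives 1000 nM, the lower of the two numbers measured. Compound 4 `Nc1nc(N)c(CCCNc2cc(F)c(F)cc2[N+](=O)[O-])c(O)n1` stands to compound 3 as compound 2 stands to compound 1, the change being (fluoro in place of nitro on an aromatic carbon), with the place of the change described in the same words as before, so it is the same change. Because the step of an at least 1.9-fold higher number from compound 1 to compound 2 (0.29 log units; that floor lies within the scatter) went toward weaker inhibition, compound 4 is expected to inhibit less strongly than compound 3, by an estimated step of a 6.0-fold higher number from compound 3 to compound 4 (0.78 log units; beyond the scatter). Compound 4 is estimated at 6000 nM, expected between 1500 nM and 40000 nM.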

Compound 4, half-maximal inhibitory concentration: 97000 nM
Beside the measured number, compound 4's estimate is 16-fold (1.21 log units) below it, outside the stated range (above it).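

In this assay, fluoro in place of nitro on an aromatic carbon gives a large step toward weaker inhibition on the core of compound 3 (a 97-fold higher number from compound 3 to compound 4 (1.99 log units; beyond the scatter)). On the core of compound 1, the assay reports a limit and not a number for compound 2 (> 100000 nM). The change therefore goes the same way on both cores, but the pair does not show whether its size carries from one core to the other: the same change on two cores in this assay, an at least 1.9-fold higher number (0.29 log units; that floor lies within the scatter) from compound 1 to compound 2 and a 97-fold higher number (1.99 log units; beyond the scatter) from compound 3 to compound 4; the limit leaves it open whether they differ.

The compounds shown leave open whether an amine, a nitrile or a carboxylic acid in place of the nitro group would give a step of similar size on these two cores. They also leave open whether the same change would go the same way on a core with a longer chain, since two pairs, one of them resting on a limit, cannot establish a rule for the series.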